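This account rests on a few compounds, and the source may have more. Where it says the series, first, only, none or still open, it means among the compounds named here.

Measured compounds in a functional assay on SNU-638 cells (Homo sapiens) for cytotoxicity, read by sulforhodamine B assay, with a stated time of 72 h; a lower number here means a stronger inhibitor, a higher number a weaker inhibitor:
Compound 1 `CCS(=O)(=O)Nc1cc(-c2ccc3ncnc(Nc4ccc(OC(F)(F)F)cc4)c3c2)cnc1OC` gives 22400 nM.
Compound 2 `CCS(=O)(=O)Nc1cc(-c2ccc3ncnc(Nc4ccc(OC)cc4)c3c2)cnc1OC` gives 3970 nM.
Compound 3 `CCS(=O)(=O)Nc1cc(-c2ccc3ncnc(Nc4ccc(OC)c(Cl)c4)c3c2)cnc1OC` gives 3620 nM.

Compound 3 sits at the low end of these three numbers, though compound 2 is within the scatter of it, as a 1.1-fold lower number from compound 2 to compound 3 (0.04 log units; within the scatter) shows. Compound 4 `CCS(=O)(=O)Nc1cc(-c2ccc3ncnc(Nc4cccc(C(=O)OC)c4)c3c2)cnc1OC` differs from compound 3 by 3-(methoxycarbonyl)phenyl in place of 3-chloro-4-methoxyphenyl on a nitrogen on an aromatic ring. For the measured compounds named here, the only steps that touch this position are a 5.6-fold lower number from compound 1 to compound 2 (0.75 log units; beyond the scatter) and a 6.2-fold lower number from compound 1 to compound 3 (0.79 log units; beyond the scatter), which show that the group on this ring can shift this assay by a modest amount, while a 1.1-fold lower number from compound 2 to compound 3 (0.04 log units; within the scatter) shows that chloro alone changes little. Going by the values given here, no measured step carries a methoxycarbonyl group, so the direction is uncertain; a modest step toward a higher number, a 1.8-fold higher number from compound 3 to compound 4 (0.25 log units; within the scatter), is expected. Compound 4 is therefore estimated at 6500 nM, with a range of 1500 nM to 28000 nM.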

Compound 4, half-maximal inhibitory concentration: 1120 nM
For compound 4 the middle estimate is 5.8-fold (0.76 log units) above the measured one; measured number below the stated range.
By their numbers in this assay, from the lowest: compound 4; then compounds 3 and 2 (each within the scatter of the next); then compound 1.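

In this assay, for the compounds shown here, the 3-(methoxycarbonyl)phenyl group gives the lowest number so far at this position: a 3.2-fold lower number from compound 3 to compound 4 (0.51 log units; beyond the scatter) and a 3.5-fold lower number from compound 2 to compound 4 (0.55 log units; beyond the scatter) both lie beyond the scatter. The step of a 20-fold lower number from compound 1 to compound 4 (1.30 log units; beyond the scatter) is large and shows that the group on this nitrogen can shift the number much further than the modest earlier steps suggested. Still open, going by these compounds, is whether a carboxylic acid or an amide in place of the methoxycarbonyl group would keep the lower number, and whether the group itself or its place on the ring matters, as both change together here. No measurement offered here explains this result.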